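A few compounds are considered here, and "the series" means these few. Any claim that something is new, unique, unknown or untested is made for them only; others in the source may bear on it.

Measured in an ADME assay (liver) for metabolic stability, with Liver microsome (Rattus norvegicus) as the target, using microsomes and NADPH, with a stated time of 30 min, at 37 degrees C, tested at 1 uM (a lower number here means slower removal, a higher number faster removal of the compound), so far:
- compound 1 `Nc1ccc(S(=O)(=O)c2ccc(-c3ncc(C(O)(C(F)(F)F)C(F)(F)F)cc3Cl)cc2)cn1` gives 18 mL.min-1.g-1
- compound 2 `COc1cc(C(O)(C(F)(F)F)C(F)(F)F)cnc1-c1ccc(S(=O)(=O)c2ccc(N)nc2)cc1` gives < 14 mL.min-1.g-1 as a limit of the assay, not a number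
- compound 3 `N#Cc1cc(C(O)(C(F)(F)F)C(F)(F)F)cnc1-c1ccc(S(=O)(=O)c2ccc(N)nc2)cc1` gives 27 mL.min-1.g-1

For the measured compounds named here, compound 3 holds one of only two true numbers in the set, and the comparison with the other is a 1.5-fold higher number from compound 1 to compound 3 (0.18 log units; within the scatter) in this series. Compound 4 `CC#Cc1cc(C(O)(C(F)(F)F)C(F)(F)F)cnc1-c1ccc(S(=O)(=O)c2ccc(N)nc2)cc1` follows from compound 3 by prop-1-yn-1-yl in place of cyano on an aromatic carbon with prop-1-yn-1-yl in place of cyano on an aromatic carbon. Three measured swaps at that same place bear on this change. Cyano in place of chloro is the step already given above. Cyano in place of methoxy is an at least 1.9-fold higher number from compound 2 to compound 3 (0.28 log units; that floor lies within the scatter) and methoxy in place of chloro is an at least 1.2-fold lower number from compound 1 to compound 2 (0.10 log units; that floor lies within the scatter) with both resting on a limit. None of these goes beyond the scatter, and none involves prop-1-yn-1-yl, so no step beyond the scatter is expected in this assay and no firm direction is claimed. The expected step is a 1.1-fold higher number from compound 3 to compound 4 (0.05 log units; within the scatter) and it stays a loose expectation. Compound 4 is estimated at 30 mL.min-1.g-1 with an expected range of 15 mL.min-1.g-1 to 60 mL.min-1.g-1 in this assay.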

Compound 4, intrinsic clearance in microsomes: 177 mL.min-1.g-1
Beside the measured number, compound 4's estimate is 5.9-fold (0.77 log units) below it; the whole stated range lies below it.
By their numbers in this assay, from the lowest: compounds 1 and 3 (each within the scatter of the next); then compound 4. At a limit, below all of these: compound 2.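

In this assay, no earlier swap at this position was shown beyond the scatter, whereas prop-1-yn-1-yl gives a 6.6-fold higher number from compound 3 to compound 4 (0.82 log units; beyond the scatter) and a 9.8-fold higher number from compound 1 to compound 4 (0.99 log units; beyond the scatter). The step of an at least 12-fold higher number from compound 2 to compound 4 (1.10 log units; beyond the scatter) gives only a floor, as compound 2 stands at a limit of the assay and not a number: the limit of < 14 mL.min-1.g-1 in this assay, at which 1 of the 4 values shown sits.
Compound 3 and compound 4 both carry a triple bond outside aromatic rings at this place, so that shared feature does not keep the read-out level.

Still open, on these data alone, is whether the rise goes with the added carbon at the end of the chain or with the absence of the nitrile nitrogen. Neither the smaller ethynyl group nor the longer but-1-yn-1-yl chain is among the compounds shown, so the shape of the trend at this place remains undefined.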